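The compounds below may be only part of what the source reports. "The series", "measured", "known", "first", "only" and "open" are said of these compounds alone.

Of the compounds shown here, three have been measured in a functional assay on HCT-15 cells (Homo sapiens) for cytotoxicity; on this read-out higher numbers stand for an effect only at larger amounts of compound and lower numbers for an effect already at smaller amounts. Compound 1 `CC1=C(O)[C@@H](C/C(C)=C\CCC(C)/C=C/C=C(\C)CCCc2ccoc2)OC1=O` gives 27.2 ug/mL. Compound 2 `CC1=C(O)/C(=C\[C@H](C)CCC/C(C)=C/CCc2coc(Cc3ccoc3)c2)OC1=O` gives 9.82 ug/mL, and compound 3 `CC1=C(O)/C(=C\[C@H](C)CC/C=C(/C)CCCc2coc(Cc3ccoc3)c2)OC1=O` gives 7.31 ug/mL. Compound 3 thus holds the lowest of the three numbers, although its number and that of compound 2 lie within the scatter of each other, whereas its gap to compound 1 lies beyond it. Compound 4 `CC1=C(O)/C(=C/[C@H](C)CC/C=C(/C)CCCc2coc(Cc3ccoc3)c2)OC1=O` differs from compound 3 in one respect: the two compounds have the same atoms and bonds and differ only in configuration as drawn: 1 of 3 stereo elements differ; a double bond is drawn E in compound 3 and Z in compound 4. Among the measured compounds shown here, no pair of measured compounds differs in a single place, so no measured step guides the expectation. The expected step of a 1.2-fold higher number from compound 3 to compound 4 (0.07 log units; within the scatter) in this assay is not beyond the scatter, with no direction preferred. Compound 4 is therefore estimated at 8.5 ug/mL, within a range from 4 ug/mL to 18 ug/mL.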

Compound 4, concentration for half-maximal effect: 4.74 ug/mL
Estimate against measurement, compound 4: 1.8-fold (0.25 log units) above, within the range that was stated.
By their numbers in this assay, from the lowest: compounds 4, 3 and 2 (each within the scatter of the next, the first and the last beyond it); then compound 1.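

Among the compounds shown here, this pair gives the first comparison that differs in a single place, and in this assay the double bond drawn E in compound 3 and Z in compound 4 gives a 1.5-fold lower number from compound 3 to compound 4 (0.19 log units; within the scatter). At this double bond, then, the drawn geometry moves the number by no more than the scatter, and the pair offers only one difference to set against that result: the fact that compounds 3 and 4 differ only in the configuration as drawn

The compounds shown leave open whether the other two stereo elements matter as little. They also leave open whether an amine or a carboxylic acid on the chain would shift the number beyond the scatter.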